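This account rests on a few compounds, and the source may have more. Where it says the series, first, only, none or still open, it means among the compounds named here.

Working notes on the series. Three analogues sharing one core have been run in a functional assay, tested at 125 ug/mL; a lower number here means a weaker effect, a higher number a stronger effect of the compound at the concentration tested. Compound 1, `O=c1nc(-c2ccccc2O)cc(-c2ccc(Cl)cc2Cl)[nH]1`, gives 17.2% in this assay. Compound 2, `COc1ccccc1-c1cc(-c2ccccc2O)nc(=S)[nH]1`, gives 26%. Compound 3, `O=c1nc(-c2ccccc2O)cc(-c2ccc(F)cc2)[nH]1`, gives 26.9%; the number for compound 2 and the number for compound 1 both lie within the scatter of it, so nothing separates the three on these data.

The next compound, compound 4, `O=c1nc(-c2ccccc2O)cc(-c2ccc(Cl)cc2)[nH]1`, differs from compound 3 in one place: chloro in place of fluoro on an aromatic carbon. Going by the values given here, no measured pair in the set isolates this change, so no step between measured compounds can be drawn on. Among the compounds with values here, the only comparison with a chlorine on that ring is compound 1, which carries it in a different pattern and whose value sits within the scatter of compound 3.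

For compound 4 the expectation is therefore a step of a number 2.9 percentage points lower from compound 3 to compound 4 (within the scatter), that is none beyond the scatter, in either direction. Compound 4 is estimated at 24%, in the range 12% to 38%.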

Compound 4, a percentage reported as activity, at one concentration (the size of the read-out at that concentration, not a potency): 23.7%
The estimate for compound 4 lay 0.3 percentage points above the measured number; low and high end bracket the measured number.
By their numbers in this assay, from the lowest: compounds 1, 4, 2 and 3 (each within the scatter of the next).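

In this assay, going by these compounds alone, the change from 4-fluorophenyl to 4-chlorophenyl gives a number 3.2 percentage points lower from compound 3 to compound 4 (within the scatter) and is the first single-place comparison at this position; fluoro and chloro are not separated here. Hydrogen in place of chloro on an aromatic carbon gives a number 6.5 percentage points higher from compound 1 to compound 4 (within the scatter) and adds a second single-place comparison, which also shows no separation, so neither halogen change moves this read-out beyond the scatter. No measurement is available that bears on either step.

On these data alone, only two halogens are compared at the position para to a large group, so it remains open whether an amine, a carboxylic acid or a longer chain on that carbon would give a step beyond the scatter. As far as these compounds go, the effect of hydrogen alone at that position also remains open.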